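A few compounds are considered here, and "the series" means these few. Any claim that something is new, unique, unknown or untested is made for them only; others in the source may bear on it.

Compound 3 `Cc1ccc(C(=O)NNC(=O)Cn2c(=O)c(Cc3ccccc3)nc3ccccc32)cc1` stands, in an assay for inhibition of Amine oxidase [flavin-containing] B (Bos taurus), read by fluorescence, with a stated time of 60 min (a higher number here means a weaker inhibitor, a lower number a stronger inhibitor), at 680000 nM. Going by the values given here, that is the lowest of the three numbers measured so far, yet the gaps to the other two lie within the scatter: compound 1 `O=C(NNc1nc2ccccc2nc1Cc1ccccc1)c1ccc(O)cc1` gives 940000 nM in this assay, and compound 2 `O=C(NNc1nc2ccccc2nc1Cc1ccccc1)c1ccc(Br)cc1` gives 980000 nM. Compound 4 `O=C(Cn1c(=O)c(Cc2ccccc2)nc2ccccc21)NNC(=O)c1ccc(Cl)cc1` is the unmeasured partner of compound 3; the change is chloro in place of methyl on an aromatic carbon, which read one bond further out is 4-methylphenyl to 4-chlorophenyl. Among the compounds with values here, only one measured step bears on an exchange of this kind on an aromatic carbon: a 1.0-fold higher number from compound 1 to compound 2 (0.02 log units; within the scatter), a halogen entering on a different core. That step is within the scatter, and the expectation is therefore a step of no size beyond the scatter, estimated as no change at the digits printed from compound 3 to compound 4 (within the scatter). Compound 4 is thus expected to give about 680000 nM in this assay, within an estimated range from 300000 nM to 1500000 nM.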

Compound 4, half-maximal inhibitory concentration: 880000 nM
Beside the measured number, compound 4's estimate is 1.3-fold (0.11 log units) below it; the range from low to high includes it.
By their numbers in this assay, from the lowest: compounds 3, 4, 1 and 2 (each within the scatter of the next).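

In this assay, chloro in place of methyl on an aromatic carbon, para to a large group, gives a 1.3-fold higher number from compound 3 to compound 4 (0.11 log units; within the scatter). Going by these compounds alone, this is the first step read on the core shared by compound 3 and compound 4, and it agrees with the only other exchange on an aromatic carbon, bromo in place of hydroxy on a different core, which gives a 1.0-fold higher number from compound 1 to compound 2 (0.02 log units; within the scatter); in neither case does the exchange of one small group for another move the number beyond the scatter. Nothing given here offers an explanation for this result.

As far as these compounds go, whether an amine, a carboxylic acid or a longer chain in this place would give a step beyond the scatter remains open. So does whether any group here could bring the number far from those of compound 3 and compound 4.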